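The source may report more compounds than this note shows. Statements on the series, on what has been measured and on what is new or still open speak of the compounds shown alone.

In a functional assay on MGC-803 cells (Homo sapiens) for antiproliferative activity, read by MTT assay, with a stated time of 72 h (a higher number here means a weaker inhibitor, a lower number a stronger inhibitor), compound 2 `O=C(NO)c1ccc(NCc2nc(-c3ccccc3)nn2-c2ccc(Br)cc2)cc1` gives 9300 nM and compound 3 `O=C(NO)c1ccc(NCc2nc(-c3cc4ccccc4s3)nn2-c2ccccc2)cc1` gives 6110 nM as values within the scatter of each other. Compound 1 `COc1ccc(-c2nc(CNc3ccc(C(=O)NO)cc3)n(-c3ccccc3)n2)cc1` gives > 20000 nM as a limit of the assay and not a number. Compound 4 `O=C(NO)c1ccc(NCc2nc(-c3ccccc3)nn2-c2ccc(F)cc2)cc1` differs from compound 2 by fluoro in place of bromo on an aromatic carbon, para to a large group fluoro in place of bromo on an aromatic carbon with the rest unchanged. Within the data shown here, the only measured step of an at least 3.2-fold lower number from compound 1 to compound 3 (0.51 log units; beyond the scatter) puts 1-benzothiophen-2-yl in place of 4-methoxyphenyl at another place, so it bears only weakly here, and no measured step exchanges bromo for fluoro. The expected step in this assay is a 1.2-fold lower number from compound 2 to compound 4 (0.07 log units; within the scatter) and it should stay within the scatter, with no firm direction. The estimate for compound 4 is 8000 nM with an expected span from 3000 nM to 20000 nM as its range.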

Compound 4, half-maximal inhibitory concentration: 10500 nM
For compound 4 the middle estimate is 1.3-fold (0.12 log units) below the measured one; the range from low to high includes it.
By their numbers in this assay, from the lowest: compounds 3, 2 and 4 (each within the scatter of the next). At a limit, above all of these: compound 1.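

In this assay, the change from 4-bromophenyl to 4-fluorophenyl gives a 1.1-fold higher number from compound 2 to compound 4 (0.05 log units; within the scatter) and is the first step shown at this place on the ring, para to a large group. Within this pair, bromo and fluoro cannot be told apart, so this exchange of one halogen for another gives no measurable step. Nothing in the data shown explains this result.

From the compounds shown here alone, whether a different group at this place, such as an amine or a carboxylic acid, would separate from these two remains open. Also open, going by these compounds, is whether the same exchange would give a similar result with the 1-benzothiophen-2-yl group of compound 3 in the molecule.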